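Methyl shift in a series at the assay limit

The compounds below may be only part of what the source reports. "The series", "measured", "known", "first", "only" and "open" are said of these compounds alone.

Of the compounds shown here, two have been read so far in a functional assay on U-87MG ATCC cells for antiproliferative activity against U-87 MG (Homo sapiens), read by spectrophotometry, with a stated time of 2 days (on this read-out lower numbers stand for stronger inhibition of growth and higher numbers for weaker inhibition of growth), on the shared core. Compound 1, `COc1ccc(C(F)(F)F)cc1Nc1ncc(C(F)(F)F)c(N2Cc3cccc(N(C)S(C)(=O)=O)c3C2)n1`, gives > 30000 nM as a limit and not a number. Compound 2, `Cc1cc(C)cc(Nc2ncc(C(F)(F)F)c(N3Cc4cccc(N(C)S(C)(=O)=O)c4C3)n2)c1`, gives > 30000 nM and this too is only a limit. Going by the values given here, the single measured change is a step that the two limits leave unreadable from compound 1 to compound 2, with 3,5-dimethylphenyl in place of 2-methoxy-5-(trifluoromethyl)phenyl on a nitrogen on an aromatic ring. Among the compounds with values here, the whole series so far stands at the limit of > 30000 nM in this assay, at which 2 of the 2 values shown sit, and offers no readable step size.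

Compound 3, `Cc1ccc(Nc2ncc(C(F)(F)F)c(N3Cc4cccc(N(C)S(C)(=O)=O)c4C3)n2)c(C)c1`, has not yet been measured. It carries 2,4-dimethylphenyl in place of 3,5-dimethylphenyl on a nitrogen on an aromatic ring, the same atoms joined differently: 2,4-dimethylphenyl in place of 3,5-dimethylphenyl on a nitrogen on an aromatic ring describes the change from compound 2.

The expectation rests on compound 2 with its limit of > 30000 nM as its only anchor. The estimate is a number no higher from compound 2 to compound 3 (the limit leaves the size open) and no step beyond the scatter is expected in either direction. For compound 3 the estimated value is 30000 nM with an expected range from 10000 nM to 60000 nM in this assay, and a report at the same limit is the likeliest outcome.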

Compound 3, concentration for 50% growth inhibition: > 30000 nM
Compound 3 gave a limit, no number; the forecaster's own chance of this, stated with the estimate: 75%; the middle value lies on the limit itself.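

In this assay compound 3 gives > 30000 nM, which is a limit and not a number. No step among compound 1, compound 2 and compound 3 can be read, as all three rest on the same value: the limit of > 30000 nM in this assay, at which 3 of the 3 values shown sit.

The compounds shown leave open whether any group on a nitrogen on an aromatic ring, on the shared core, gives a readable value in this assay.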